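The compounds below may be only part of what the source reports. "The series", "measured", "known", "first", "only" and "open" are said of these compounds alone.

Values measured in a functional assay on CLL cells (Homo sapiens) for cytotoxicity, read by MTT assay, with a stated time of 48 h; on this read-out higher numbers stand for an effect only at larger amounts of compound and lower numbers for an effect already at smaller amounts:
- compound 1 `C=C(CC)C(=O)c1ccc(OCC(=O)NCCCN2CCCC2=O)c(Cl)c1Cl`: 13800 nM
- compound 2 `C=C(CC)C(=O)c1ccc(OCC(=O)Nc2nc3ccccc3s2)c(Cl)c1Cl`: 1500 nM
- compound 3 `C=C(CC)C(=O)c1ccc(OCC(=O)Nc2ccc(C(C)=O)cc2)c(Cl)c1Cl`: 3900 nM

Compound 3 sits in the middle of this short series, with a number higher than that of compound 2 and lower than that of compound 1. The next compound, compound 4 `C=C(CC)C(=O)c1ccc(OCC(=O)NO)c(Cl)c1Cl`, keeps the shared core and changes one group: hydroxy in place of 4-acetylphenyl on an amide-type nitrogen. Hydroxy takes the place of 4-acetylphenyl on an amide-type nitrogen.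

All three measured steps change the group at this same nitrogen. They are a 9.2-fold lower number from compound 1 to compound 2 (0.96 log units; beyond the scatter), a 3.5-fold lower number from compound 1 to compound 3 (0.55 log units; beyond the scatter) and a 2.6-fold higher number from compound 2 to compound 3 (0.41 log units; beyond the scatter). Each is modest but beyond the scatter, so this group clearly matters in this assay. For the measured compounds named here, none of the measured groups is as small as hydroxy, however, so the direction remains uncertain. Judging from the size of a 3.5-fold lower number from compound 1 to compound 3 (0.55 log units; beyond the scatter), a modest step is expected, more likely towards a higher number than a lower one. The expected change is a 1.5-fold higher number from compound 3 to compound 4 (0.19 log units; within the scatter). Compound 4 is estimated at 6000 nM, with an expected range of 2000 nM to 18000 nM.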

Compound 4, half-maximal effective concentration: 4500 nM
For compound 4 the middle estimate is 1.3-fold (0.12 log units) above the measured one; low and high end bracket the measured number.
By their numbers in this assay, from the lowest: compound 2; then compounds 3 and 4 (each within the scatter of the next); then compound 1.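

In this assay, removing the whole 4-acetylphenyl group, with its six-membered aromatic ring, and leaving only hydroxy on the amide-type nitrogen gives a 1.2-fold higher number from compound 3 to compound 4 (0.06 log units; within the scatter) and so no readable change. The size of the group alone therefore does not set the number in this short series: hydroxy, the smallest group here, gives a 3.0-fold higher number from compound 2 to compound 4 (0.48 log units; beyond the scatter) but also a 3.1-fold lower number from compound 1 to compound 4 (0.49 log units; beyond the scatter) and so stays clear of both compound 2 and compound 1. Nothing available explains why these groups fall in this order.

The compounds shown leave open whether an aromatic ring at this nitrogen helps at all, since compound 2 alone stands clearly below compound 4 and a plain phenyl group does not appear among them. They also leave open how an amine, a carboxylic acid or a simple methyl group would behave at this nitrogen.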